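The source may report more compounds than this note shows. Statements on the series, on what has been measured and on what is new or still open speak of the compounds shown alone.

Measured so far in an assay on isolated protein for inhibition of histamine H2 receptor (Cavia porcellus); a higher number here means weaker binding, a lower number tighter binding:
- compound 1 `O=C(NCCCOc1cccc(CN2CCCCC2)c1)Nc1cccc(C(F)(F)F)c1`: 813 nM
- compound 2 `O=C(NCCCOc1cccc(CN2CCCCC2)c1)NCc1ccccc1`: 347 nM
- compound 3 `COc1ccc(OC)c(NC(=O)NCCCOc2cccc(CN3CCCCC3)c2)c1`: 158 nM

Compound 3 gives the lowest number of the three. Its nearest neighbour is compound 2, as a 2.2-fold lower number from compound 2 to compound 3 (0.34 log units; beyond the scatter); its furthest is compound 1, as a 5.1-fold lower number from compound 1 to compound 3 (0.71 log units; beyond the scatter). All three share the same core and differ only in the group on the urea-type nitrogen.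

Compound 4 `CCCNC(=O)NCCCOc1cccc(CN2CCCCC2)c1` is not yet measured. It differs from compound 3 in one place: propyl in place of 2,5-dimethoxyphenyl on an amide-type nitrogen.

Among the measured compounds shown here, two measured steps bear on this change, both at the same nitrogen. The first, a 2.3-fold lower number from compound 1 to compound 2 (0.37 log units; beyond the scatter), shows that moving from an aromatic ring directly on the nitrogen to a ring carried on one carbon lowers the number modestly. The second, a 2.2-fold lower number from compound 2 to compound 3 (0.34 log units; beyond the scatter), shows a further modest lowering when the 2,5-dimethoxyphenyl group comes in. For the measured compounds named here, no measured step removes the ring altogether, so the propyl case has no direct precedent here. Given that the two lowest numbers belong to compounds carrying a ring, a step back towards a higher number is expected for compound 4 in this assay, of modest size: a 2.8-fold higher number from compound 3 to compound 4 (0.45 log units; beyond the scatter). The estimate for compound 4 is 450 nM, with a range from 150 nM to 1400 nM.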

Compound 4, dissociation constant: 97.7 nM
Compound 4: the middle estimate sits 4.6-fold (0.66 log units) above what was measured, outside the stated range (below it).
By their numbers in this assay, from the lowest: compounds 4 and 3 (each within the scatter of the next); then compound 2; then compound 1.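

In this assay, a ring on the amide-type nitrogen proves dispensable: propyl, with 3 heavy atoms and no ring, replaces the 10-heavy-atom 2,5-dimethoxyphenyl in a 1.6-fold lower number from compound 3 to compound 4 (0.21 log units; within the scatter) and the two compounds cannot be told apart. The ring-free group also stands clear of the other two ring-bearing groups, with a 3.6-fold lower number from compound 2 to compound 4 (0.55 log units; beyond the scatter) and an 8.3-fold lower number from compound 1 to compound 4 (0.92 log units; beyond the scatter) as the steps, so the presence of a ring does not sort this small set: compound 3 keeps its ring and still sits level with compound 4, while compound 1 and compound 2 go against any link between a ring and a low number. Nothing available explains why a small saturated chain does as well as the 2,5-dimethoxyphenyl group here.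

Open, going by these compounds, is how far the chain tolerates change at this nitrogen: whether methyl, a longer chain such as hexyl, or a branched chain such as isopropyl stays at this level. Equally open, on these data alone, is whether a chain ending in an amine or a carboxylic acid, or a saturated ring such as cyclohexyl, holds the number in this assay or moves it.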